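Chloro on the Benzyl Ether: Cytotoxicity Expected to Stay Flat

The source may hold more compounds than are shown below. What is called first, only, known or untested is meant among the compounds shown, and "the series" means these compounds.

Compound 1, `O=C(O)/C(O)=C/C(=O)c1cccc(OCc2ccc(Cl)cc2)c1`: in an ADME assay on Huh-7 cells (Homo sapiens) for cytotoxicity (on this read-out higher numbers stand for lower toxicity in this test and lower numbers for higher toxicity in this test), compound 1 gives > 100000 nM, which is a limit of the assay and not a number.
Compound 2, `O=C(O)/C(O)=C/C(=O)c1ccccc1OCc1ccccc1`: in this assay compound 2 gives > 100000 nM, again a limit rather than a number.

Compound 2 therefore stands at the upper edge of what this assay can report, together with compound 1, as summed up by the limit of > 100000 nM in this assay, at which 2 of the 2 values shown sit. Compound 3, `O=C(O)/C(O)=C/C(=O)c1ccccc1OCc1ccc(Cl)cc1`, differs from compound 2 in one place: chloro in place of hydrogen on an aromatic carbon, a chloro in place of hydrogen on an aromatic carbon. Since both measured compounds sit at the same limit, no basis exists for expecting a shift in this assay beyond the usual scatter, in either direction. The step of a number no higher from compound 2 to compound 3 (the limit leaves the size open) is thus expected to be essentially none. For compound 3 the estimated value is 100000 nM, with a range from 40000 nM to 300000 nM, most likely reported again as a limit.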

Compound 3, half-maximal cytotoxic concentration: > 100000 nM
Compound 3: no number, only a limit; the forecaster's own chance of this, stated with the estimate: 85%; the middle value sits exactly at the limit.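

Among the compounds shown here, no step from compound 2 to compound 3 can be read in this assay: both results are limits of the assay, not numbers. The compounds shown leave open whether chloro in place of hydrogen changes the read-out at all, and at what concentration any of them would show toxicity.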